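The source may report more compounds than this note shows. Statements on the series, on what has been measured and on what is new or still open speak of the compounds shown alone.

Measured so far, in a functional assay on MCF7 cells (Homo sapiens) for cytotoxicity, read by MTT assay, with a stated time of 48 h; on this read-out lower numbers stand for stronger inhibition and higher numbers for weaker inhibition:
- compound 1 `O=C(Nc1ccc(Cl)cc1)c1cn(-c2ccccc2)nc1-c1ccccc1` gives 3860 nM
- compound 2 `CCOc1ccc(NC(=O)c2cn(-c3ccccc3)nc2-c2ccccc2)cc1` gives 880 nM

Among the compounds with values here, compound 2 holds the lower of these two numbers; the only measured step, a 4.4-fold lower number from compound 1 to compound 2 (0.64 log units; beyond the scatter), sits on the anilide ring. Compound 3 `CCOc1ccc(NC(=O)c2cn(-c3ccccc3)nc2-c2ccc(OC)cc2)cc1` differs from compound 2 by methoxy in place of hydrogen on an aromatic carbon, a change on a different ring of the shared core. Within the data shown here, no measured step touches that ring, so there is nothing to point in either direction, and the expected step of a 1.0-fold higher number from compound 2 to compound 3 (0.01 log units; within the scatter) is none beyond the scatter. Compound 3 is therefore estimated at 900 nM, within 300 nM to 2700 nM.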

Compound 3, half-maximal inhibitory concentration: 1100 nM
For compound 3 the middle estimate is 1.2-fold (0.09 log units) below the measured one; the range from low to high includes it.
By their numbers in this assay, from the lowest: compounds 2 and 3 (each within the scatter of the next); then compound 1.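

In this assay the change from phenyl to 4-methoxyphenyl gives a 1.3-fold higher number from compound 2 to compound 3 (0.10 log units; within the scatter), so this ring accepts a methoxy group without a change that can be told from the scatter. The earlier step showed a difference only on the anilide ring, whereas this position shows none for this one group. No measurement here bears on the reason for this result.

As far as these compounds go, whether an amine or a carboxylic acid at this same place would also leave the number unchanged stays open. So does whether methoxy here would give the same result with the chloro group of compound 1 on the anilide ring.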